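Acetyl to dimethylamino on the distal phenyl of the series

The compounds below may be only part of what the source reports. "The series", "measured", "known", "first", "only" and "open" are said of these compounds alone.

Measured compounds:
compound 1 `COc1cc(C)cc(-c2c(-c3ccnc(-c4ccc(C(C)=O)cc4)c3)cnn2CC#N)c1`, 4960 nM
compound 2 `Cc1cc(O)cc(-c2nn(CC#N)cc2-c2ccnc(-c3ccc(Oc4ccccc4)cc3)c2)c1`, 9900 nM

Two compounds of this series carry numbers in a functional assay on SK-MEL-5 cells (Homo sapiens) for inhibition, read by sulforhodamine B assay, with a stated time of 48 h; on this read-out lower numbers stand for stronger inhibition of growth and higher numbers for weaker inhibition of growth. Compound 1 gives 4960 nM, the lower of the two. Compound 2 gives 9900 nM, and the gap between compound 1 and compound 2 lies within the scatter of repeated measurements, so no order between the two can be read from these figures. The two compounds differ in more than one place, so nothing about any single change can be taken from them.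

Compound 3 `COc1cc(C)cc(-c2c(-c3ccnc(-c4ccc(N(C)C)cc4)c3)cnn2CC#N)c1` is not yet measured in this assay. It departs from compound 1 in one place: dimethylamino in place of acetyl on an aromatic carbon. Among the measured compounds shown here, no pair of measured compounds shows this change, and no other step between measured compounds is available, so there is no precedent for its size or direction. The expectation is therefore anchored on compound 1 alone. For compound 3 the estimate in this assay is 5000 nM, with a range from 1500 nM to 16000 nM. The step from compound 1 to compound 3 is expected to be a 1.0-fold higher number from compound 1 to compound 3 (0.00 log units; within the scatter), that is, no move beyond the scatter in either direction.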

Compound 3, concentration for total growth inhibition: 309 nM
For compound 3 the middle estimate is 16-fold (1.21 log units) above the measured one; measured number outside the range, below it.
By their numbers in this assay, from the lowest: compound 3; then compounds 1 and 2 (each within the scatter of the next).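

In this assay, among the compounds shown here, the exchange of 4-acetylphenyl for 4-(dimethylamino)phenyl gives a 16-fold lower number from compound 1 to compound 3 (1.21 log units; beyond the scatter), the first step that can be assigned to a single change. This shows that the place on the aromatic ring para to a large group is not indifferent to the group it carries, since a change here alone separates compound 3 from compound 1 by more than the usual scatter. The two groups match in heavy-atom count, hydrogen-bond donors, hydrogen-bond acceptors and net charge, so these counts do not distinguish them; they differ in the oxygen of the acetyl and its double bond outside the aromatic rings, set against the nitrogen of the dimethylamino group, and no measurement available here explains the size of the step.

From the compounds shown here alone, this remains a single pair, so it is open whether the step belongs to dimethylamino specifically or would also appear with methylamino, a cyclic amine such as morpholine, or a methoxy group at the same place. Going by these compounds, it is equally open whether the step would hold on any core other than that of compound 1.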